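Swapping Isopropyl for 4-Fluorophenyl on the Five-Membered Ring

The source may report more compounds than this note shows. Statements on the series, on what has been measured and on what is new or still open speak of the compounds shown alone.

Compound 1 `CC(C)n1nc(-c2ccon2)c2c(N)ncnc21`: 7920 nM
Compound 2 `CC(C)n1nc(-c2cc(C(C)(C)C)on2)c2c(N)ncnc21`: > 10000 nM
Compound 3 `CC(C)c1cc(-c2nn(C(C)C)c3ncnc(N)c23)no1`: 5130 nM

In an assay on TT cells for inhibition of proto-oncogene tyrosine-protein kinase receptor Ret variant C634W (Homo sapiens), read by MTT assay, with a stated time of 10 days (on this read-out lower numbers stand for stronger inhibition of growth and higher numbers for weaker inhibition of growth), compound 1 gives 7920 nM. Compound 2 reaches only the limit of > 10000 nM, so no number is known for it (the limit of > 10000 nM in this assay, at which 1 of the 3 values shown sits). Compound 3 gives 5130 nM, the lower of the two numbers, yet the step of a 1.5-fold lower number from compound 1 to compound 3 (0.19 log units; within the scatter) stays within the scatter. Compound 4 `CC(C)n1nc(-c2cc(-c3ccc(F)cc3)on2)c2c(N)ncnc21` differs from compound 3 in one place: 4-fluorophenyl in place of isopropyl on an aromatic carbon. The measured changes at this position, an at least 1.2-fold higher number from compound 1 to compound 2 (0.10 log units; that floor lies within the scatter) and a 1.5-fold lower number from compound 1 to compound 3 (0.19 log units; within the scatter), as well as an at least 1.9-fold lower number from compound 2 to compound 3 (0.28 log units; that floor lies within the scatter), all remained within the scatter. For compound 4 the step of a 1.3-fold higher number from compound 3 to compound 4 (0.10 log units; within the scatter) is therefore expected to be small, with no clear direction. Compound 4 is estimated at 6500 nM, between 2500 nM and 15000 nM.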

Compound 4, concentration for 50% growth inhibition: > 10000 nM
Compound 4: only a limit was reported; the forecaster's own chance of this, stated with the estimate: 30%; at least 1.5-fold (0.18 log units) between middle value and limit.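

Compound 4 reaches only a limit, the second at this position after the tert-butyl of compound 2: the limit of > 10000 nM in this assay, at which 2 of the 4 values shown sit. The steps of an at least 1.9-fold higher number from compound 3 to compound 4 (0.28 log units; that floor lies within the scatter) and an at least 1.2-fold higher number from compound 1 to compound 4 (0.10 log units; that floor lies within the scatter) have floors that stay within the scatter, so even an added aromatic ring shows no change here beyond the scatter, though the true steps may be larger. Compound 2 and compound 4 both sit at limits, so the step between them cannot be read. Still open, as far as these compounds go, is whether an amine or a carboxylic acid on this carbon would bring the number clearly down.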